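Amide cap exchange in a trifluoromethyl ketone hydrate series

This account rests on a few compounds, and the source may have more. Where it says the series, first, only, none or still open, it means among the compounds named here.

Compound 1 `O=C(CCCCCCNC(=O)C(O)(O)C(F)(F)F)Nc1ccncc1` is the anchor of these notes. Among the measured compounds shown here, in a functional assay on HCT-116 cells (Homo sapiens) for inhibition, read by colorimetric assay, with a stated time of 3 days (a lower number here means a stronger inhibitor, a higher number a weaker inhibitor), compound 1 gives 6670 nM, and this is the only value in the set that is a number. Compound 2 `OC(O)(c1c(F)c(F)c(-n2cc(-c3ccccc3)nn2)c(F)c1F)C(F)(F)F`, built on a different scaffold, gives in this assay only a limit, > 100000 nM. That limit is recorded as the limit of > 100000 nM in this assay, at which 1 of the 2 values shown sits, and offers no number to compare against compound 1. For the measured compounds named here, no pair of measured compounds differing in a single place is available, so no measured step sets the scale for what a change at the amide cap does.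

Compound 3 `O=C(CCCCCCNC(=O)C(O)(O)C(F)(F)F)Nc1nc2ccccc2s1` is the untested partner of compound 1. The change is 1,3-benzothiazol-2-yl in place of pyridin-4-yl on an amide-type nitrogen, with the amide-type nitrogen and the rest of the chain left as they are. Nothing measured in this set shows how such a cap exchange plays out, so the expectation rests on compound 1 alone. A modest gain, beyond the scatter but not large, is expected in this assay, the step from compound 1 to compound 3 being estimated as a 2.2-fold lower number from compound 1 to compound 3 (0.35 log units; beyond the scatter). Compound 3 is therefore expected to give 3000 nM, within a range of 800 nM to 12000 nM.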

Compound 3, half-maximal inhibitory concentration: 2370 nM
Beside the measured number, compound 3's estimate is 1.3-fold (0.10 log units) above it; the range from low to high includes it.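

In this assay, the exchange of pyridin-4-yl for 1,3-benzothiazol-2-yl on the amide-type nitrogen gives a 2.8-fold lower number from compound 1 to compound 3 (0.45 log units; beyond the scatter) and is the only measured step shown at this position. The step shows that inhibition in the series does not depend on keeping pyridin-4-yl as the cap: a cap of 9 heavy atoms with two aromatic rings replaces one of 6 heavy atoms with one aromatic ring, and the number moves modestly towards a stronger inhibitor, with the shared chain and trifluoromethyl ketone hydrate unchanged. Nothing measured here accounts for the size of this step or ties it to any one feature of the incoming group.

With a single step, the compounds shown leave open which part of 1,3-benzothiazol-2-yl carries the change, since the five-membered ring with its sulfur and the carbon-only six-membered ring enter together. A thiazol-2-yl or phenyl cap on the same nitrogen would separate those parts, and a longer chain under the benzothiazolyl cap would show whether the step holds when the rest of the molecule changes.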